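Taking one chloro group off compound 3

The source may hold more compounds than are shown below. What is called first, only, known or untested is meant among the compounds shown, and "the series" means these compounds.

In an ADME assay for permeability, using PAMPA (on this read-out lower numbers stand for lower permeability and higher numbers for higher permeability), compound 1 `O=C(Nc1ccc(F)cc1)c1cc(Cl)ccc1O` gives 391 10^-6 cm/s. Compound 2 `NS(=O)(=O)c1ccc(NC(=O)c2cc(Cl)ccc2O)cc1` returns only a limit, < 1 10^-6 cm/s. Compound 3 `O=C(Nc1ccc(Cl)cc1Cl)c1cc(Cl)ccc1O` also returns only a limit, < 22.4 10^-6 cm/s, so no exact number fixes its standing. Among the measured compounds shown here, the one measured step, an at least 390-fold lower number from compound 1 to compound 2 (2.59 log units; beyond the scatter), is large, but it exchanges different groups and bears only loosely on what follows. Compound 4 `O=C(Nc1ccc(Cl)cc1)c1cc(Cl)ccc1O` differs from compound 3 by hydrogen in place of chloro on an aromatic carbon, ortho to a large group. Compound 1, at 391 10^-6 cm/s, shows that high numbers occur among these compounds, so a rise is expected. The expected step in this assay is an at least 4.4-fold higher number from compound 3 to compound 4 (0.64 log units; beyond the scatter). Compound 4 is estimated at 100 10^-6 cm/s, within an expected range of 15 10^-6 cm/s to 400 10^-6 cm/s.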

Compound 4, apparent permeability in the ADME assay: 297 10^-6 cm/s
Compound 4: the middle estimate sits 3.0-fold (0.47 log units) below what was measured; low and high end bracket the measured number.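

In the ADME assay, hydrogen in place of chloro, ortho to a large group, brings an at least 13-fold higher number from compound 3 to compound 4 (1.12 log units; beyond the scatter), a step read against a limit: the limit of < 22.4 10^-6 cm/s in the ADME assay, at which 1 of the 4 values shown sits. In the ADME assay, the new compound also gives a 1.3-fold lower number from compound 1 to compound 4 (0.12 log units; within the scatter), and the same read-out gives an at least 290-fold higher number from compound 2 to compound 4 (2.47 log units; beyond the scatter), so chloro and fluoro stay together far from sulfamoyl. In a physicochemical assay for solubility (on this read-out lower numbers stand for lower solubility and higher numbers for higher solubility), compound 3 returns only a limit, < 1 ug/mL. In the physicochemical assay, compound 4 also returns only a limit, < 1 ug/mL. In the physicochemical assay, the step between compound 3 and compound 4 cannot be read: the limit of < 1 ug/mL in the physicochemical assay, at which 2 of the 2 values shown sit.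

Open, as far as these compounds go, is whether a methyl or methoxy group, ortho to a large group, would keep the high number in the ADME assay. Open too, from the compounds shown here alone, is whether an amine would bring a readable number in the physicochemical assay.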